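Adding a second benzyloxy group to compound 2

This account rests on a few compounds, and the source may have more. Where it says the series, first, only, none or still open, it means among the compounds named here.

Values in a functional assay, read by spectrophotometry, with a stated time of 5 min (a lower number here means a stronger inhibitor, a higher number a weaker inhibitor), so far:
Compound 1 `O=c1cc(/C=N\Nc2ccc([N+](=O)[O-])cc2)c2ccc(OCc3ccccc3)cc2o1` gives > 2000000 nM as a limit of the assay
Compound 2 `O=c1cc(/C=N\Nc2ccc([N+](=O)[O-])cc2[N+](=O)[O-])c2ccc(OCc3ccccc3)cc2o1` gives 181000 nM as a measured number

Among the compounds with values here, compound 2 at 181000 nM holds the only true number so far in this assay. Compound 3 `O=c1cc(/C=N\Nc2ccc([N+](=O)[O-])cc2[N+](=O)[O-])c2c(OCc3ccccc3)cc(OCc3ccccc3)cc2o1` differs from compound 2 by benzyloxy in place of hydrogen on an aromatic carbon in one place, ortho to a fused ring and meta to a benzyloxy group. Within the data shown here, the one measured step is an at least 11-fold lower number from compound 1 to compound 2 (1.04 log units; beyond the scatter) and it is large, yet it brought in a nitro group and not a benzyloxy group, so it sets no size or direction for this change. Compound 2 at 181000 nM remains the only anchor, and no shift beyond the scatter is expected. The estimated step is a 1.2-fold lower number from compound 2 to compound 3 (0.08 log units; within the scatter) in this assay with either direction open. Compound 3 is expected at 150000 nM with an estimated range from 30000 nM to 800000 nM overall.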

Compound 3, half-maximal inhibitory concentration: 292000 nM
For compound 3 the middle estimate is 1.9-fold (0.29 log units) below the measured one; the measured number falls inside the stated range.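

In this assay, benzyloxy in place of hydrogen, ortho to a fused ring and meta to a benzyloxy group, gives a 1.6-fold higher number from compound 2 to compound 3 (0.21 log units; within the scatter). Within the data shown here, this is the first reading at this position, since the earlier step concerned a nitro group, and it shows that the position carries a benzyloxy group of 8 heavy atoms with no shift beyond the scatter, while compound 3 still gives a true number. The data shown offer nothing that explains this result.

Going by these compounds, whether a different group at this position, such as an amine, a carboxylic acid or a longer chain, would shift the number beyond the scatter stays open. Also open, on these data alone, is whether the added benzyloxy group would behave the same way on a compound without the second nitro group.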